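This account rests on a few compounds, and the source may have more. Where it says the series, first, only, none or still open, it means among the compounds named here.

Measured so far in an ADME assay on L02 cells (Homo sapiens) for cytotoxicity, read by MTT assay; a lower number here means a stronger inhibitor, a higher number a weaker inhibitor:

Compound 1, `COc1ccc(/C=C/C(=O)c2ccc(OC)c3c2OC(C)(C)C=C3)cc1OCC=C(C)C`, gives > 10000 nM, which is a limit of the assay rather than a number.
Compound 2, `COc1ccc(/C=C/C(=O)c2ccc(OC)c3c2OC(C)(C)C=C3)cc1OCCCN(C)C`, gives 8600 nM.
Compound 3, `COc1ccc(/C=C/C(=O)c2ccc(OC)c3c2OC(C)(C)C=C3)cc1OC(=O)c1ccc(Br)cc1`, has not yet been measured.

Compound 2 stands alone among these compounds with an actual number in this assay; the other value reported is a limit. Among the compounds with values here, the only step measured so far is an at least 1.1-fold lower number from compound 1 to compound 2 (0.06 log units; that floor lies within the scatter), and it lies within the scatter, so it gives no sign of a real shift between the two. Compound 1 sits at the limit of > 10000 nM in this assay, at which 1 of the 2 values shown sits.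

Compound 3 differs from compound 2 in one place: (4-bromophenyl)carbonyl in place of 3-(dimethylamino)propyl on an oxygen on an aromatic ring. Within the data shown here, no measured step involves a carbonyl-bearing group on this oxygen, so nothing here points to a change beyond the scatter in either direction. Among the measured compounds shown here, the one step available, an at least 1.1-fold lower number from compound 1 to compound 2 (0.06 log units; that floor lies within the scatter), was small.

Compound 3 is therefore estimated at 9000 nM, with a range from 3000 nM to 30000 nM. The expected step is a 1.0-fold higher number from compound 2 to compound 3 (0.02 log units; within the scatter), within the usual scatter, and there is a fair chance that this assay reports only a limit for compound 3.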

Compound 3, half-maximal inhibitory concentration: 8400 nM
Compound 3: the middle estimate sits 1.1-fold (0.03 log units) above what was measured, and the stated range covers the measured number.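

In this assay, the oxygen on an aromatic ring accepts two quite different groups with no sign of a difference: putting (4-bromophenyl)carbonyl in place of 3-(dimethylamino)propyl gives a 1.0-fold lower number from compound 2 to compound 3 (0.01 log units; within the scatter). The group that leaves has no ring and carries a nitrogen, while the group that enters brings a six-membered aromatic ring, a bromine and a carbonyl, so these differences at this position do not separate compound 2 from compound 3 in this read-out. The other new comparison, an at least 1.1-fold lower number from compound 1 to compound 3 (0.07 log units; that floor lies within the scatter), gives only a floor and cannot be read as a real shift because compound 1 sits at a limit: the limit of > 10000 nM in this assay, at which 1 of the 3 values shown sits.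

On these data alone, it remains open whether any group on this oxygen can move the number beyond the scatter, for example a free hydroxyl, a longer amine chain or a chain ending in a carboxylic acid. As far as these compounds go, the part played by the bromine is also open, and a phenylcarbonyl or a (4-chlorophenyl)carbonyl on the same oxygen would be the comparison that speaks to it.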